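This account rests on a few compounds, and the source may have more. Where it says the series, first, only, none or still open, it means among the compounds named here.

Among the measured compounds shown here, compound 2 `COc1ccc(OC[C@@H]2CCN2)cn1` gives 1.3 nM in an assay on brain for binding affinity to Neuronal acetylcholine receptor; alpha4/beta2 (Rattus norvegicus), read by radioligand binding (on this read-out lower numbers stand for stronger inhibition and higher numbers for weaker inhibition), the lowest of the two numbers so far, though the gap to compound 1 `N#Cc1ccc(OC[C@@H]2CCN2)cn1`, which gives 1.9 nM, lies within the scatter. For the measured compounds named here, the single step measured at that ring carbon, a 1.5-fold lower number from compound 1 to compound 2 (0.16 log units; within the scatter), is small. Compound 3 `c1ccc(-c2ccc(OC[C@@H]3CCN3)cn2)cc1` differs from compound 2 by phenyl in place of methoxy on an aromatic carbon. Going by the values given here, no measured step puts a phenyl there, so the earlier step bears only weakly on it. A modest rise in the number is therefore expected, a 7.7-fold higher number from compound 2 to compound 3 (0.89 log units; beyond the scatter). Compound 3 is estimated at 10 nM, in the range 2 nM to 50 nM.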

Compound 3, inhibition constant: 2.3 nM
Compound 3: middle estimate off by 4.3-fold (0.64 log units), on the high side; the range from low to high includes it.
By their numbers in this assay, from the lowest: compounds 2, 1 and 3 (each within the scatter of the next).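

Replacing methoxy with phenyl raises the heavy-atom count at this ring carbon from 2 to 6 and adds a six-membered aromatic ring, yet the step stays small (a 1.8-fold higher number from compound 2 to compound 3 (0.25 log units; within the scatter)). The step from cyano to phenyl is also small (a 1.2-fold higher number from compound 1 to compound 3 (0.08 log units; within the scatter)). Methoxy, cyano and phenyl therefore stand level at this position in this assay, and no evidence is available to explain this. As far as these compounds go, whether an amine, a carboxylic acid or a longer chain at this carbon would stay level with them remains open. Also open, from the compounds shown here alone, is whether this holds when the shared core is changed elsewhere.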